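From 4-methylphenyl to 3-methoxyphenyl on the aromatic nitrogen

The compounds below may be only part of what the source reports. "The series", "measured", "known", "first", "only" and "open" are said of these compounds alone.

Measured in a functional assay on MDA-MB-468 cells (Homo sapiens) for antiproliferative activity, read by MTT assay, with a stated time of 72 h (on this read-out higher numbers stand for weaker inhibition and lower numbers for stronger inhibition), so far:
Compound 1 `CCCn1ccnc1-c1cc(OC)c(OC)c(OC)c1` gives > 100000 nM as a limit
Compound 2 `COc1cc(-c2nccn2Cc2ccccc2)cc(OC)c1OC` gives > 100000 nM as a limit
Compound 3 `COc1cc(-c2nccn2-c2ccc(C)cc2)cc(OC)c1OC` gives 400 nM as a number

Beyond compound 3 the set offers only the limit of > 100000 nM in this assay, at which 2 of the 3 values shown sit, and no second number. The open case is compound 4 `COc1cccc(-n2ccnc2-c2cc(OC)c(OC)c(OC)c2)c1` with the change 3-methoxyphenyl in place of 4-methylphenyl on an aromatic nitrogen at that same place. Within the data shown here, two measured steps concern this nitrogen, an at least 250-fold lower number from compound 1 to compound 3 (2.39 log units; beyond the scatter) and an at least 250-fold lower number from compound 2 to compound 3 (2.39 log units; beyond the scatter) in turn. Both are large, yet neither exchanges one substituted phenyl for another. Compound 3 at 400 nM shares a substituted phenyl on that nitrogen with compound 4, so a step of that size is not expected. A modest move toward weaker inhibition is expected, a 2.0-fold higher number from compound 3 to compound 4 (0.30 log units; within the scatter) on this estimate. Compound 4 is estimated at 800 nM and expected to fall between 150 nM and 5000 nM as a working range.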

Compound 4, half-maximal inhibitory concentration: 10400 nM
Compound 4: middle estimate off by 13-fold (1.11 log units), on the low side, outside the stated range (above it).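

In this assay, one substituted phenyl does not stand in for another on this aromatic nitrogen: 3-methoxyphenyl in place of 4-methylphenyl gives a 26-fold higher number from compound 3 to compound 4 (1.41 log units; beyond the scatter). Even so, 3-methoxyphenyl still reads better than the other two groups, with an at least 9.6-fold lower number from compound 2 to compound 4 (0.98 log units; beyond the scatter) for benzyl and an at least 9.6-fold lower number from compound 1 to compound 4 (0.98 log units; beyond the scatter) for propyl. These two steps give only a minimum size, as compound 1 and compound 2 each stand at a limit and not at a number: the limit of > 100000 nM in this assay, at which 2 of the 4 values shown sit.

The compounds shown leave open whether the weaker inhibition belongs to the methoxy group itself or to where it sits on the phenyl. 4-Methoxyphenyl or 3-methylphenyl on this nitrogen would separate the two.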